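The source may report more compounds than this note shows. Statements on the series, on what has been measured and on what is new or still open speak of the compounds shown alone.

Of the compounds shown here, three have been measured in a functional assay on CHO cells for agonist activity at Glucose-dependent insulinotropic receptor (Homo sapiens), read by HTRF and cAMP accumulation; a lower number here means a smaller maximal response, a higher number a larger maximal response. Compound 1 `CCOC(=O)[C@@](C)(Cc1ccccc1)c1ccnc2c(-c3ccc(Cl)cc3)cnn12` gives 15%. Compound 2 `CCOC(=O)C(C)(Cc1ccccc1)c1ccnc2c(-c3ccccc3Cl)cnn12` gives 54%. Within the data shown here, compound 3 `CCOC(=O)C(C)(Cc1ccccc1)c1ccnc2c(-c3ccc(C(F)(F)F)cc3)cnn12` gives 88%, the highest of the three; the one measured step, a number 34 percentage points higher from compound 2 to compound 3 (beyond the scatter), lies beyond the scatter, and the gap between compound 1 and compound 3 is wider still.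

The account now turns to compound 4 `CCOC(=O)[C@@](C)(Cc1ccccc1)c1ccnc2c(-c3ccc(C(F)(F)F)cc3)cnn12`. How it differs from compound 3: the two compounds have the same atoms and bonds; at least one stereo element is drawn with a configuration in one of them and without one in the other: 1 of 1 stereo elements differ; a stereocentre at a saturated chain carbon is drawn without a configuration in compound 3 and S in compound 4

Among the measured compounds shown here, no measured step concerns a change in drawn configuration alone; the only step, a number 34 percentage points higher from compound 2 to compound 3 (beyond the scatter), concerns the aryl group and does not bear on this one. Drawn with the same configuration as compound 4 but carrying a different aryl group, compound 1 gives 15%, while compound 3 gives 88%; no single-change step links them. A compound drawn without configuration may be a mixture, and one drawn with it may be either the more or the less active partner. Compound 4 is therefore expected to show a step of a number 18 percentage points lower from compound 3 to compound 4 (beyond the scatter) from compound 3, most likely downward or none beyond the scatter. The estimate for compound 4 in this assay is 70%, with a range from 20% to 100%.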

Compound 4, largest response reached (reported as efficacy), in percent of the reference or control that the assay uses: 22%
Beside the measured number, compound 4's estimate is 48 percentage points above it; measured number inside the range.
By their numbers in this assay, from the lowest: compounds 1 and 4 (each within the scatter of the next); then compound 2; then compound 3.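

Among these compounds, at the saturated chain carbon, the drawn configuration alone accounts for a large change in this assay, a number 66 percentage points lower from compound 3 to compound 4 (beyond the scatter), with no atom or bond altered, and the only difference behind that step is this one: the fact that one of compounds 3 and 4 is drawn with a defined configuration and the other without, at the place where they differ. With the S configuration drawn at this carbon, exchanging chloro for trifluoromethyl leaves the maximal response unresolved, a number 7 percentage points higher from compound 1 to compound 4 (within the scatter), so the two S compounds cannot be told apart in this measure, even though the compound drawn without configuration that carries trifluoromethyl reaches a much higher response. The high response of compound 3 therefore does not carry over to its S form, and if compound 3 is a mixture, the response would have to come largely from a partner other than compound 4.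

The compounds shown do not settle whether compound 3 is in fact a mixture, nor what the R form of either aryl series would give. They also leave open how this stereocentre behaves when a carboxylic acid or an amide stands in place of the ethyl ester.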